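A few compounds are considered here, and "the series" means these few. Any claim that something is new, unique, unknown or untested is made for them only; others in the source may bear on it.

In a functional assay on U-251 cells (Homo sapiens) for antiproliferative activity, read by sulforhodamine B assay, with a stated time of 48 h (a lower number here means a stronger inhibitor, a higher number a weaker inhibitor), compound 1 `O=C(NCCCNc1cc(-c2cn(-c3ccccc3)nc2-c2cccc(O)c2)ccn1)Nc1ccc(F)cc1` gives 2050 nM. Among the compounds with values here, the only other measured compound, compound 2 `O=C(NCCCNc1cc(-c2cn(-c3ccccc3)nc2-c2cccc(O)c2)ccn1)Nc1cccc(C(F)(F)F)c1`, gives 2570 nM. These two numbers lie within the scatter of each other, so the data do not separate compound 1 from compound 2. The next compound to test is compound 3 `COc1cccc(-c2nn(-c3ccccc3)cc2-c2ccnc(NCCCNC(=O)Nc3ccc(F)cc3)c2)c1`, which keeps the shared core of compound 1 and differs in one place: methyl in place of hydrogen on an oxygen on an aromatic ring. The 3-hydroxyphenyl of compound 1 thus becomes the 3-methoxyphenyl of compound 3. Within the data shown here, the one measured step, a 1.3-fold higher number from compound 1 to compound 2 (0.10 log units; within the scatter), is small, but it concerns a group on an amide-type nitrogen, not this oxygen. Among the measured compounds shown here, it therefore offers only weak guidance, and no measured pair tests hydroxy to methoxy directly. With so little evidence, no step beyond the scatter is expected in this assay, and no direction can be firmly predicted. The expected change is small: a 1.2-fold higher number from compound 1 to compound 3 (0.09 log units; within the scatter). For compound 3 the estimated value is 2500 nM, with an expected range of 1000 nM to 6500 nM.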

Compound 3, half-maximal inhibitory concentration: 9840 nM
Estimate against measurement, compound 3: 3.9-fold (0.60 log units) below, and the stated range ends below it.
By their numbers in this assay, from the lowest: compounds 1 and 2 (each within the scatter of the next); then compound 3.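

Replacing the hydrogen on this oxygen with methyl, so that hydroxy becomes methoxy, gives a 4.8-fold higher number from compound 1 to compound 3 (0.68 log units; beyond the scatter) in this assay. This is the first step shown that lies beyond the scatter, whereas the change on the amide-type nitrogen, a 1.3-fold higher number from compound 1 to compound 2 (0.10 log units; within the scatter), did not separate its two compounds, so the 3-hydroxyphenyl is a place where adding a single carbon to the molecule visibly alters the number in this assay. No measurement at hand explains why capping this oxygen raises the number, so the step stands as an observation and not as an explanation.

With only one replacement shown at this oxygen, it remains open whether the free hydroxy itself matters or whether methyl is simply one of many groups that would raise the number; an amine in place of the hydroxy, or a longer chain such as ethyl on the oxygen, would help tell these readings apart. From the compounds shown here alone, it is also open whether the same change would raise the number to a similar extent in compound 2, which carries the 3-(trifluoromethyl)phenyl group on the amide-type nitrogen.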